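Cytotoxicity notes: from compound 2 to compound 3

The source may hold more compounds than are shown below. What is called first, only, known or untested is meant among the compounds shown, and "the series" means these compounds.

Among the compounds with values here, both compounds measured so far share one core and were tested in an ADME assay on HepG2 cells (Homo sapiens) for cytotoxicity, read by luminescence, CellTiter-Glo and ATP content, with a stated time of 72 h; on this read-out lower numbers stand for an effect already at smaller amounts and higher numbers for an effect only at larger amounts of compound. Compound 1 `COc1ccccc1Oc1ccc2c(NCCCNCc3ccco3)ccnc2c1` gives 6500 nM in this assay. Compound 2 `Fc1ccc(-c2ccc3c(NCCCNCc4ccco4)ccnc3c2)cc1` gives 7760 nM in this assay, the highest of the two numbers, with compound 1 nearest. Within the data shown here, the only measured step, a 1.2-fold higher number from compound 1 to compound 2 (0.08 log units; within the scatter), replaces 2-methoxyphenoxy with 4-fluorophenyl on an aromatic carbon and stays within the scatter.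

Compound 3 `Fc1ccc(Cc2ccc3c(NCCCNCc4ccco4)ccnc3c2)c(Cl)c1` is not yet measured. It differs from compound 2 by 2-chloro-4-fluorobenzyl in place of 4-fluorophenyl on an aromatic carbon. Among the measured compounds shown here, no measured step changes the same aromatic carbon in this way, so the bearing of the one known step is indirect: the change from compound 1 to compound 2 at the same place left this assay unchanged beyond the scatter, which suggests that a second variation at that position may also give a small step.

The step expected from compound 2 to compound 3 is a 1.2-fold lower number from compound 2 to compound 3 (0.08 log units; within the scatter), no more than the scatter. Compound 3 is therefore estimated at 6500 nM in this assay, with a range from 3000 nM to 14000 nM.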

Compound 3, half-maximal effective concentration: 5730 nM
The estimate for compound 3 lay 1.1-fold (0.05 log units) above the measured number; the range from low to high includes it.
By their numbers in this assay, from the lowest: compounds 3, 1 and 2 (each within the scatter of the next).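

With 2-chloro-4-fluorobenzyl as a third group at this aromatic carbon, this assay gives a 1.4-fold lower number from compound 2 to compound 3 (0.13 log units; within the scatter) and a 1.1-fold lower number from compound 1 to compound 3 (0.05 log units; within the scatter), so all three groups seen here lie within the scatter of one another. The earlier pair rested on a single step, whereas three pairwise comparisons now point the same way for compounds 1, 2 and 3, with none going against it. Replacing 4-fluorophenyl, with its 7 heavy atoms, by the 9 heavy atoms of 2-chloro-4-fluorobenzyl, which adds a chlorine, does not take the number beyond the scatter. Nothing available explains why these groups read so alike.

Going by these compounds, each of the three groups carries a six-membered aromatic ring of carbon only, so it remains open whether an amine or a carboxylic acid at this aromatic carbon would stay within the same range. The rest of the structure is the same in all three compounds, which leaves open how this read-out responds to a change elsewhere, such as a longer chain.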